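A few compounds are considered here, and "the series" means these few. Any claim that something is new, unique, unknown or untested is made for them only; others in the source may bear on it.

Working notes on a small series built on a shared core and read in an ADME assay on MCF-10A cells (Homo sapiens) for cytotoxicity, read by MTT assay, with a stated time of 72 h (on this read-out lower numbers stand for stronger inhibition and higher numbers for weaker inhibition), as the only assay. In this assay compound 1 `Cc1cccc(-n2c(-c3coc4cc(C)c(Cl)cc4c3=O)nc(-c3ccccc3)c2-c2ccccc2)c1` has the entry "not determined" (no result reported) and offers no number to work with. Compound 2 `Cc1ccc(-n2c(-c3coc4cc(C)c(Cl)cc4c3=O)nc(-c3ccccc3)c2-c2ccccc2)c(C)c1` likewise has the entry "not determined" (no result reported) and gives no basis for comparison. Within the data shown here, compound 3 `Cc1cc2occ(-c3nc(-c4ccccc4)c(-c4ccccc4)n3-c3ccc(Cl)cc3)c(=O)c2cc1Cl` gives 92000 nM in this assay and this is the only number, so it cannot be ranked against any neighbour.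

Compound 4 `Cc1cc2occ(-c3nc(-c4ccccc4)c(-c4ccccc4)n3-c3ccc(Br)cc3)c(=O)c2cc1Cl` has not yet been measured and differs from compound 3 in one place: bromo in place of chloro on an aromatic carbon with bromo in place of chloro on an aromatic carbon, so that 4-chlorophenyl becomes 4-bromophenyl, para to a large group. Among the measured compounds shown here, no measured pair differs in one place, which leaves no direct precedent for the size of such a step. The expectation therefore rests on compound 3 at 92000 nM as the sole anchor, and no change beyond the scatter is expected in this assay for this exchange. The estimated step of a 1.0-fold lower number from compound 3 to compound 4 (0.02 log units; within the scatter) is accordingly small and has no firm direction. Compound 4 is estimated at 88000 nM with 40000 nM to 190000 nM as the expected range.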

Compound 4, half-maximal inhibitory concentration: > 100000 nM
Compound 4 ended at the assay's limit; the forecaster's own chance of this, stated with the estimate: 25%; middle value at least 1.1-fold (0.05 log units) away from the limit.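

In this assay compound 4 gives > 100000 nM, which is a limit of the assay and not a number. Among these compounds, the exchange of chloro for bromo on an aromatic carbon, para to a large group, turning 4-chlorophenyl into 4-bromophenyl, provides the first one-place step, an at least 1.0-fold higher number from compound 3 to compound 4 (0.03 log units; that floor lies within the scatter), so this position has now been read with two halogens, but the floor does not separate them and the true size of the step stays unknown. The result also shows that this series reaches the edge of the measurable range at this position, so a further change here could be lost to the limit rather than read as a step: the limit of > 100000 nM in this assay, at which 1 of the 4 values shown sits.

As far as these compounds go, compounds 1 and 2 have no number, so any comparison with them cannot be read, and the effect of the methyl groups on the N-aryl ring remains unknown in this assay. Also open, from the compounds shown here alone, is whether an amine or a carboxylic acid in place of the bromo of compound 4 would give a number inside the range, and in which direction it would lie from compound 3.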